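A few compounds are considered here, and "the series" means these few. Any claim that something is new, unique, unknown or untested is made for them only; others in the source may bear on it.

Measured so far:

Compound 1 `c1ccc(Cn2c(CCc3c[nH]c4ccccc34)nnc2C2CCNCC2)cc1`
Compound 2 `NCCCc1nnc(CCc2c[nH]c3ccccc23)n1Cc1ccc(Cl)c(Cl)c1`
Compound 3 `Clc1ccc(Cn2c(CCc3c[nH]cn3)nnc2CCc2c[nH]c3ccccc23)cc1Cl`

In an assay on cells for displacement of a labelled ligand from somatostatin receptor type 2 (Homo sapiens), with a stated time of 90 min (a lower number here means a stronger inhibitor, a higher number a weaker inhibitor), compound 1 gives > 10000 nM, a limit of the assay rather than a number. In this assay compound 2 gives > 10000 nM, again a limit. In this assay compound 3 gives > 10000 nM, also a limit. Compound 3 therefore stands at the limit with the other two; the limit of > 10000 nM in this assay, at which 3 of the 3 values shown sit, holds for all three shown, and the one step within the set, a step that the two limits leave unreadable from compound 2 to compound 3, cannot be read because both ends sit at that limit.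

Compound 4 `Clc1ccc(Cn2c(CCc3c[nH]c4ccccc34)nnc2C2CCNCC2)cc1Cl` is not yet measured. It differs from compound 3 by piperidin-4-yl in place of 2-(1H-imidazol-4-yl)ethyl on an aromatic carbon. Compound 1 already carries the piperidin-4-yl group on the shared core and gives only a limit in this assay, so the group entering here has not so far brought a number below the limit. Within the data shown here, no measured step gives a readable size, and no change beyond the scatter can be predicted for a step that the limit leaves unreadable from compound 3 to compound 4; the expectation is that compound 4 also returns a limit. The estimate for compound 4 in this assay is 15000 nM, expected between 4000 nM and 60000 nM.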

Compound 4, inhibition constant: > 10000 nM
Compound 4: no number, only a limit (the forecaster's own chance of this, stated with the estimate: 85%); the middle value lies beyond the limit too.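

In this assay, among these compounds, compound 4 gives > 10000 nM, a limit and not a number, so no step from compound 1, compound 2 or compound 3 to compound 4 can be read: the limit of > 10000 nM in this assay, at which 4 of the 4 values shown sit. The compounds shown leave open which change on the shared core, if any, would give a measurable value.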